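The source may hold more compounds than are shown below. What is called first, only, known or untested is meant among the compounds shown, and "the series" means these compounds.

Compound 2 `O=C1CC1N1CCCC(c2ccccc2)(C2CCN(Cc3ccc(Br)cc3)CC2)C1`: 180 nM
Compound 1 `O=C(N1CCCC(c2ccccc2)(C2CCN(Cc3ccc(Br)cc3)CC2)C1)C(F)(F)F`: 690 nM

In a functional assay on CHO cells for antagonist activity at C-X-C chemokine receptor type 3 (Homo sapiens), read by GTPgammaS binding, with a stated time of 30 min (a higher number here means a weaker inhibitor, a lower number a stronger inhibitor), compound 2 gives the lowest of the two numbers shown, with compound 1 at 690 nM nearest to it. Within the data shown here, the one measured step at this ring nitrogen is a 3.8-fold lower number from compound 1 to compound 2 (0.58 log units; beyond the scatter). Compound 3 `NC(=O)N1CCCC(c2ccccc2)(C2CCN(Cc3ccc(Br)cc3)CC2)C1` differs from compound 2 by carbamoyl in place of 2-oxocyclopropyl on an amine nitrogen in a ring. Among the measured compounds shown here, no measured step covers carbamoyl here, so the direction is uncertain; since the only change at this position moved the number modestly, the step is expected to be small. For compound 3 the estimate is 300 nM, in the range 100 nM to 900 nM, which means an expected step of a 1.7-fold higher number from compound 2 to compound 3 (0.22 log units; within the scatter).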

Compound 3, half-maximal inhibitory concentration: 250 nM
For compound 3 the middle estimate is 1.2-fold (0.08 log units) above the measured one; measured number inside the range.
By their numbers in this assay, from the lowest: compounds 2 and 3 (each within the scatter of the next); then compound 1.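

Carbamoyl on the amine nitrogen in the ring cannot be told apart from 2-oxocyclopropyl: in this assay the change is a 1.4-fold higher number from compound 2 to compound 3 (0.14 log units; within the scatter). Amino in place of trifluoromethyl on the carbonyl carbon gives a 2.8-fold lower number from compound 1 to compound 3 (0.44 log units; beyond the scatter), so among these three compounds, only compound 1 stands apart, with both other groups at this nitrogen beyond the scatter from it. No evidence on any property of these groups bears on these steps. The compounds shown leave open how an acetyl group, a methylsulfonyl group or a simple alkyl chain on this nitrogen would compare.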